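The compounds below may be only part of what the source reports. "The series", "measured", "known", "first", "only" and "open" are said of these compounds alone.

Measured compounds:
Compound 1 `COc1cc(OC)c(OC)cc1/C=C/C(=O)c1ccc(C)cc1`: 42200 nM
Compound 2 `COc1cc(OC)c(OC)cc1/C=C/C(=O)c1cc(Cl)ccc1O`: > 150000 nM, a limit of the assay
Compound 3 `COc1cc(OC)c(OC)cc1/C=C/C(=O)c1ccc(O)cc1O`: 37600 nM

In a functional assay on HeLa cells (Homo sapiens) for inhibition, read by MTT assay, with a stated time of 72 h (on this read-out higher numbers stand for weaker inhibition and lower numbers for stronger inhibition), compound 1 stands highest of the two numbers; nearest is compound 3, a difference within the scatter. Compound 4 `COc1cc(OC)c(OC)cc1/C=C/C(=O)c1ccc([N+](=O)[O-])cc1` carries one change from compound 1: nitro in place of methyl on an aromatic carbon. Among the compounds with values here, no measured step varies a single ring substituent in this way; both known steps replace the whole ring on the carbonyl carbon. Of these, an at least 3.5-fold higher number from compound 1 to compound 2 (0.55 log units; beyond the scatter) is beyond the scatter, while a 1.1-fold lower number from compound 1 to compound 3 (0.05 log units; within the scatter) is within it. Neither gives direct guidance for nitro in place of methyl, so a step within the scatter is expected, a 1.1-fold lower number from compound 1 to compound 4 (0.02 log units; within the scatter). Compound 4 is therefore estimated at 40000 nM, between 10000 nM and 150000 nM.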

Compound 4, half-maximal inhibitory concentration: > 150000 nM
Compound 4 was reported as a limit; the forecaster's own chance of this, stated with the estimate: 20%; middle value at least 3.7-fold (0.57 log units) from the limit.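

In this assay, nitro in place of methyl on an aromatic carbon, para to a large group, gives an at least 3.5-fold higher number from compound 1 to compound 4 (0.55 log units; beyond the scatter). This is the first step shown that keeps the ring on the carbonyl carbon and changes one substituent, and that single change alone moves the number beyond the scatter. The value of compound 4 is a limit and not a number, so the full size of the step stays unread: the limit of > 150000 nM in this assay, at which 2 of the 4 values shown sit.

From the compounds shown here alone, whether an amine, a carboxylic acid or a longer chain in place of methyl at this position stays near compound 1 remains open. The compounds shown also leave open what the nitro group itself contributes to the step.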